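Cyclohexyl to tert-butyl on the isoxazole-bearing series

The source may report more compounds than this note shows. Statements on the series, on what has been measured and on what is new or still open speak of the compounds shown alone.

Compound 1 `CC(C)n1nc(/C=N/O)c2c(N)ncnc21` gives, in an assay on isolated protein for inhibition of proto-oncogene tyrosine-protein kinase receptor Ret (Homo sapiens), read by radiometric assay and 33P incorporation, in the presence of a further agent that is not named here (a higher number here means a weaker inhibitor, a lower number a stronger inhibitor), a value of 4900 nM. Compound 2 `CC(C)n1nc(-c2cc(C3CCCCC3)on2)c2c(N)ncnc21` gives 910 nM in this assay, the lower of the two numbers, and its gap to compound 1 lies beyond the scatter. Compound 3 `CC(C)n1nc(-c2cc(C(C)(C)C)on2)c2c(N)ncnc21` has not been measured; it differs from compound 2 by tert-butyl in place of cyclohexyl on an aromatic carbon. Within the data shown here, with no measured pair of this kind at hand, a modest loss is expected, so that a 1.6-fold higher number from compound 2 to compound 3 (0.22 log units; within the scatter) is estimated as a small step toward weaker inhibition. Compound 3 is expected to give about 1500 nM in this assay, within a range from 600 nM to 4000 nM.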

Compound 3, half-maximal inhibitory concentration: 210 nM
The estimate for compound 3 lay 7.1-fold (0.85 log units) above the measured number; the measured number lies below the stated range.
By their numbers in this assay, from the lowest: compound 3; then compound 2; then compound 1.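

In this assay, the aromatic carbon next to the ring oxygen responds clearly to the group it carries: tert-butyl in place of cyclohexyl gives a 4.3-fold lower number from compound 2 to compound 3 (0.64 log units; beyond the scatter). A six-membered non-aromatic ring is therefore not required at this position for inhibition, and the open-chain group with fewer carbons does better here. Nothing at hand accounts for this step.

From the compounds shown here alone, whether methyl, an amine or a carboxylic acid at this position would extend or reverse the step remains open. This single pair also cannot show whether the step holds with other groups on the shared core.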